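Acyl group variation on the shared core

The source may hold more compounds than are shown below. What is called first, only, known or untested is meant among the compounds shown, and "the series" means these compounds.

Compound 1 `CC(=O)O[C@]12C=CC(=O)C[C@H]1OCC2`: 0.5 ug/mL
Compound 2 `CCCCCC(=O)O[C@]12C=CC(=O)C[C@H]1OCC2`: 0.3 ug/mL

In a functional assay on P388 cells (Mus musculus) for cytotoxicity (on this read-out higher numbers stand for weaker inhibition and lower numbers for stronger inhibition), compound 1 gives 0.5 ug/mL; compound 2 gives 0.3 ug/mL. Compound 2 stands at the lower of the two numbers, but the step of a 1.7-fold lower number from compound 1 to compound 2 (0.22 log units; within the scatter) is within the scatter, so the two are not separated. Compound 3 `O=C1C=C[C@]2(OC(=O)c3ccccc3)CCO[C@@H]2C1` is not yet measured and differs from compound 2 in one place: phenyl in place of pentyl on a carbonyl carbon. Among the compounds with values here, the only step that bears on this is a 1.7-fold lower number from compound 1 to compound 2 (0.22 log units; within the scatter), a small one, and pentyl to phenyl on that carbonyl carbon is untested. No step beyond the scatter is therefore expected: a 1.3-fold higher number from compound 2 to compound 3 (0.12 log units; within the scatter). For compound 3 the estimate is 0.4 ug/mL, with a range from 0.15 ug/mL to 1.2 ug/mL.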

Compound 3, half-maximal inhibitory concentration: 0.5 ug/mL
Beside the measured number, compound 3's estimate is 1.3-fold (0.10 log units) below it; measured number inside the range.
By their numbers in this assay, from the lowest: compounds 2, 1 and 3 (each within the scatter of the next).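

In this assay, within the data shown here, a ring stands on the carbonyl carbon for the first time, and the number does not leave the scatter against either open-chain group (a 1.7-fold higher number from compound 2 to compound 3 (0.22 log units; within the scatter); no change at the digits printed from compound 1 to compound 3 (within the scatter)). Methyl, pentyl and phenyl at this place are therefore not separated, so neither chain length nor a six-membered aromatic ring of carbon only has yet shown a step beyond the scatter. Nothing available explains this flat result.

Going by these compounds, whether a carboxylic acid or an amine on the phenyl, or a chain longer than pentyl, would give a step beyond the scatter remains open. Changes to the shared core itself also remain open.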